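Imidazole-Carbonitrile Imines: Swapping an Aryl for a Benzyl

A few compounds are considered here, and "the series" means these few. Any claim that something is new, unique, unknown or untested is made for them only; others in the source may bear on it.

Compound 1 `COc1ccc(OC)c(/C=N/c2c(C#N)ncn2-c2ccc(F)cc2)c1` and compound 2 `COc1cc(/C=N/c2c(C#N)ncn2-c2ccc(F)cc2)ccc1O` share a core but differ in the substituted benzylidene portion; that difference between the two cores is not broken down here. In a functional assay on T47D cells (Homo sapiens) for antiproliferative activity, read by MTT assay, with a stated time of 48 h (a lower number here means a stronger inhibitor, a higher number a weaker inhibitor), compound 1 gives 16300 nM and compound 2 gives 20100 nM, values within the usual scatter of one another. Compound 3 `COc1ccc(OC)c(/C=N/c2c(C#N)ncn2Cc2ccc(F)cc2)c1` carries the change (4-fluorobenzyl in place of 4-fluorophenyl on an aromatic nitrogen), and the measured step is a 1.4-fold higher number from compound 1 to compound 3 (0.14 log units; within the scatter), with compound 3 giving 22400 nM in this assay. Compound 4 `COc1cc(/C=N/c2c(C#N)ncn2Cc2ccc(F)cc2)ccc1O` arises from compound 2 by the same kind of change, (4-fluorobenzyl in place of 4-fluorophenyl on an aromatic nitrogen), at the same place. Because the step of a 1.4-fold higher number from compound 1 to compound 3 (0.14 log units; within the scatter) stayed within the scatter, the expected step of a 1.3-fold higher number from compound 2 to compound 4 (0.11 log units; within the scatter) is likewise small. Compound 4 is therefore estimated at 26000 nM in this assay, with a plausible range from 13000 nM to 52000 nM.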

Compound 4, half-maximal inhibitory concentration: 21500 nM
Compound 4: the middle estimate sits 1.2-fold (0.08 log units) above what was measured; low and high end bracket the measured number.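

On the second core, the change gives a 1.1-fold higher number from compound 2 to compound 4 (0.03 log units; within the scatter) in this assay. Set beside the earlier step, the two cores show no difference in how the change carries over: the same change on two cores in this assay, a 1.4-fold higher number (0.14 log units; within the scatter) from compound 1 to compound 3 and a 1.1-fold higher number (0.03 log units; within the scatter) from compound 2 to compound 4, 1.3-fold (0.11 log units) apart, within the scatter of two such steps. This shows only that replacing 4-fluorophenyl with 4-fluorobenzyl stayed within the scatter on both cores shown; it does not show that the change would behave the same way on any other core, and neither step offers a shift beyond the scatter to carry across.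

The compounds shown leave open whether a longer chain ending in an amine or a carboxylic acid on that aromatic nitrogen would move the number beyond the scatter. Going by these compounds, the separate contribution of the substituents on the benzylidene portion also remains open.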